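The source may hold more compounds than are shown below. What is called first, only, known or untested is meant among the compounds shown, and "the series" means these compounds.

Measured compounds:
compound 1 `O=C(Nc1nc2ccc(F)cc2s1)c1cn(-c2ccccc2)nc1-c1ccc(F)cc1`, 5260 nM
compound 2 `O=C(Nc1nc2ccc(Cl)cc2s1)c1cn(-c2ccccc2)nc1-c1ccc(F)cc1`, 3170 nM
compound 3 `COc1ccc(-c2nn(-c3ccccc3)cc2C(=O)Nc2nc3ccc(F)cc3s2)cc1`, 4930 nM

Three compounds were tested in a functional assay on PC-3 cells (Homo sapiens) for cytotoxicity, read by MTT assay, with a stated time of 72 h; on this read-out higher numbers stand for weaker inhibition and lower numbers for stronger inhibition. Compound 1 gives 5260 nM, compound 2 gives 3170 nM and compound 3 gives 4930 nM. The change from compound 1 to compound 2 is this one: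
chloro in place of fluoro on an aromatic carbon
It produced a 1.7-fold lower number from compound 1 to compound 2 (0.22 log units; within the scatter). The cores of compound 1 and compound 3 differ as follows:
methoxy in place of fluoro on an aromatic carbon
That change produced a 1.1-fold lower number from compound 1 to compound 3 (0.03 log units; within the scatter). Compound 4 `COc1ccc(-c2nn(-c3ccccc3)cc2C(=O)Nc2nc3ccc(Cl)cc3s2)cc1` has not yet been measured in this assay . It differs from compound 3 in this way:
chloro in place of fluoro on an aromatic carbon
For the measured compounds named here, this is the same change as the one from compound 1 to compound 2, made on the same place. Since that earlier step was within the usual scatter, a step of about the same size is expected from compound 3 to compound 4, namely a 1.6-fold lower number from compound 3 to compound 4 (0.22 log units; within the scatter), because the same change gave a 1.7-fold lower number from compound 1 to compound 2 (0.22 log units; within the scatter). On this basis compound 4 is estimated at 3000 nM in this assay , with a likely range from 1500 nM to 6500 nM.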

Compound 4, half-maximal inhibitory concentration: 6510 nM
Compound 4: middle estimate off by 2.2-fold (0.34 log units), on the low side, and the stated range ends below it.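

In this assay, for the compounds shown here, chloro in place of fluoro on the core carrying the methoxy group gave a 1.3-fold higher number from compound 3 to compound 4 (0.12 log units; within the scatter), and this step does not separate from the earlier one: the same change on two cores in this assay, a 1.7-fold lower number (0.22 log units; within the scatter) from compound 1 to compound 2 and a 1.3-fold higher number (0.12 log units; within the scatter) from compound 3 to compound 4, 2.2-fold (0.34 log units) apart, within the scatter of two such steps Methoxy in place of fluoro on the core carrying the chloro group gave a 2.1-fold higher number from compound 2 to compound 4 (0.31 log units; beyond the scatter), the only one of these steps beyond the scatter, yet the gap to its earlier counterpart stays within it: the same change on two cores in this assay, a 1.1-fold lower number (0.03 log units; within the scatter) from compound 1 to compound 3 and a 2.1-fold higher number (0.31 log units; beyond the scatter) from compound 2 to compound 4, 2.2-fold (0.34 log units) apart, within the scatter of two such steps Neither change therefore shows a real dependence on the core, but with a single pair of small steps for each change, this does not show that either one carries over reliably from core to core.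

The compounds shown leave open whether a nitrile or an amine in place of the chloro would give a step clearly beyond the scatter. They also leave open whether a carboxylic acid in place of the methoxy would behave the same way on both cores.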